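Chloro in place of fluoro: compound 3 to compound 4

A few compounds are considered here, and "the series" means these few. Any claim that something is new, unique, unknown or untested is made for them only; others in the source may bear on it.

Compound 1 `CCNC(=O)Nc1sc2ccccc2c1C(=O)N1CCN(C2CCN(C(=O)OC(C)C)CC2)CC1`: 3%
Compound 2 `CCNC(=O)Nc1sc2cc(C(F)(F)F)ccc2c1C(=O)N1CCN(C2CCN(C(=O)C(C)(C)C(F)(F)F)CC2)CC1`: 7%
Compound 3 `CCNC(=O)Nc1sc2cc(F)ccc2c1C(=O)N1CCN(C2CCN(C(=O)C(C)(C)C(F)(F)F)CC2)CC1`: 17%
Compound 4 `CCNC(=O)Nc1sc2cc(Cl)ccc2c1C(=O)N1CCN(C2CCN(C(=O)C(C)(C)C(F)(F)F)CC2)CC1`: not yet measured

In an ADME assay on microsomes from liver (Homo sapiens) for metabolic stability, read by LC-MS, with a stated time of 15 min (a higher number here means that more of the compound is left, a lower number that less of the compound is left), compound 3 gives 17%. Compound 2 gives 7%, and its gap to compound 3 lies within the scatter. Compound 1 gives 3%, and its gap to compound 3 lies beyond the scatter.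

Compound 4 differs from compound 3 by one substitution: chloro in place of fluoro on an aromatic carbon. For the measured compounds named here, only one measured step bears on this change: a number 10 percentage points higher from compound 2 to compound 3 (within the scatter), with fluoro in place of trifluoromethyl on an aromatic carbon. That step stayed within the scatter. Going by the values given here, no measured compound carries chloro, so the evidence is indirect, and no change beyond the scatter is expected in this assay. The estimated step is a number 5 percentage points lower from compound 3 to compound 4 (within the scatter), a small drop that would remain within the scatter. For compound 4 the estimate is 12%, with an expected range of 4% to 24%.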

Compound 4, percent of the compound remaining: 51%
Beside the measured number, compound 4's estimate is 39 percentage points below it; measured number outside the range, above it.
By their numbers in this assay, from the lowest: compounds 1, 2 and 3 (each within the scatter of the next, the first and the last beyond it); then compound 4.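

In this assay the identity of the single atom on this aromatic carbon turns out to matter a great deal: chloro in place of fluoro brings a number 34 percentage points higher from compound 3 to compound 4 (beyond the scatter) while the earlier change at this carbon, a number 10 percentage points higher from compound 2 to compound 3 (within the scatter), gave no such clear shift. Chloro in place of trifluoromethyl brings a number 44 percentage points higher from compound 2 to compound 4 (beyond the scatter) so among the three groups seen at this carbon, chloro alone stands clearly apart from the other two. Nothing measured here accounts for why this one-atom exchange has so large an effect.

Going by these compounds, it remains open whether bromo, methyl, methoxy or nitrile on the same carbon would match chloro. On these data alone, it is also open whether chloro would give a similar result on another carbon of this six-membered aromatic ring, or with a different group at the far end of the molecule.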